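A few compounds are considered here, and "the series" means these few. Any claim that something is new, unique, unknown or untested is made for them only; others in the source may bear on it.

Compound 3 `COc1ccc(C(=O)/C=C/c2cc(-c3cc(OC)c(OC)c(OC)c3)n[nH]2)cc1` gives 3750 nM in a functional assay on NCI-H460 cells (Homo sapiens) for inhibition, read by sulforhodamine B assay, with a stated time of 48 h (on this read-out higher numbers stand for weaker inhibition of growth and lower numbers for stronger inhibition of growth), the lowest of the three numbers seen so far. Compound 1 `COc1cc(-c2cc(/C=C/C(=O)c3ccc(N)cc3)[nH]n2)cc(OC)c1OC` gives 5100 nM in this assay, which lies within the scatter of compound 3; compound 2 `COc1cc(-c2cc(/C=C/C(=O)c3ccc(Cl)c(Cl)c3)[nH]n2)cc(OC)c1OC` gives 36600 nM, the furthest from compound 3, since the step of a 9.8-fold lower number from compound 2 to compound 3 (0.99 log units; beyond the scatter) lies beyond the scatter. Compound 4 `COc1cc(-c2cc(/C=C/C(=O)c3ccc(F)c(F)c3)[nH]n2)cc(OC)c1OC` differs from compound 3 by 3,4-difluorophenyl in place of 4-methoxyphenyl on a carbonyl carbon. The nearest guide is the pair of steps that swapped this same group: the step of a 7.2-fold higher number from compound 1 to compound 2 (0.86 log units; beyond the scatter) and the step of a 9.8-fold lower number from compound 2 to compound 3 (0.99 log units; beyond the scatter). Both show that a 3,4-dichlorophenyl on the carbonyl carbon gave a higher number than 4-aminophenyl or 4-methoxyphenyl. By analogy, the step of a 4.8-fold higher number from compound 3 to compound 4 (0.68 log units; beyond the scatter) is expected. Compound 4 is therefore estimated at 18000 nM, with a likely range from 6000 nM to 55000 nM.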

Compound 4, concentration for total growth inhibition: 8240 nM
The estimate for compound 4 lay 2.2-fold (0.34 log units) above the measured number, within the range that was stated.
By their numbers in this assay, from the lowest: compounds 3, 1 and 4 (each within the scatter of the next, the first and the last beyond it); then compound 2.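

Changing the two chlorines of 3,4-dichlorophenyl to fluorines gives a 4.4-fold lower number from compound 2 to compound 4 (0.65 log units; beyond the scatter), so having two halogens on this ring does not by itself produce the high number of compound 2. Replacing 4-methoxyphenyl with 3,4-difluorophenyl costs only a little, with a 2.2-fold higher number from compound 3 to compound 4 (0.34 log units; beyond the scatter). Replacing 4-aminophenyl with the same ring gives a 1.6-fold higher number from compound 1 to compound 4 (0.21 log units; within the scatter), a step within the scatter. On these data alone, how a ring with a single fluorine, a trifluoromethyl or a carboxylic acid would behave at this carbonyl carbon remains open. No measurement available here explains these differences.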